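The source may report more compounds than this note shows. Statements on the series, on what has been measured and on what is new or still open speak of the compounds shown alone.

In a functional assay on the whole organism for inhibition, with Scenedesmus acutus as the target (on this read-out lower numbers stand for stronger inhibition and higher numbers for weaker inhibition), compound 3 (`CCCCOC(=O)c1cc(N2C(=O)C3=C(CCCC3)C2=O)ccc1Cl`) gives 6310 nM and stands highest of the three measured numbers, with compound 1 (`O=C(O)c1cc(N2C(=O)C3=C(CCCC3)C2=O)c(F)cc1Cl`) at 1000 nM and compound 2 (`COC(=O)c1cc(N2C(=O)C3=C(CCCC3)C2=O)c(F)cc1Cl`) at 67.6 nM both lower, beyond the scatter.

Compound 4 (`CCCCOC(=O)c1cc(N2C(=O)C3=C(CCCC3)C2=O)c(F)cc1Cl`) differs from compound 3 in one place: fluoro in place of hydrogen on an aromatic carbon This is fluoro in place of hydrogen on an aromatic carbon, ortho to a large group and para to the butoxycarbonyl group.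

Within the data shown here, no measured step isolates this change. Among the measured compounds shown here, the only measured step, a 15-fold lower number from compound 1 to compound 2 (1.17 log units; beyond the scatter), is large, but it exchanges hydrogen for methyl on the acid and keeps the fluoro group throughout, so it bears only indirectly. The indirect evidence is that both fluoro compounds lie lower than compound 3, with compound 1 at 1000 nM and compound 2 at 67.6 nM in this assay. Against this, compound 2 and compound 3 also differ in the ester, and the data do not separate the butyl ester from the fluoro group.

A large expected step toward a lower number is therefore estimated, a 42-fold lower number from compound 3 to compound 4 (1.62 log units; beyond the scatter), with wide uncertainty. Compound 4 is expected at 150 nM within an estimated range from 40 nM to 800 nM in this read-out.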

Compound 4, half-maximal inhibitory concentration: 126 nM
Estimate against measurement, compound 4: 1.2-fold (0.08 log units) above; measured number inside the range.
By their numbers in this assay, from the lowest: compounds 2 and 4 (each within the scatter of the next); then compound 1; then compound 3.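

In this assay, among these compounds, a 50-fold lower number from compound 3 to compound 4 (1.70 log units; beyond the scatter) gives the first direct reading of this change: with the butyl ester held fixed, fluoro in place of hydrogen on the aromatic carbon para to a butoxycarbonyl group accounts for a large step toward stronger inhibition. With the fluoro group present in both compounds, a 1.9-fold higher number from compound 2 to compound 4 (0.27 log units; within the scatter) stays within the scatter when the methyl ester is extended to the butyl ester, so these two esters are not separated here, whereas a 7.9-fold lower number from compound 1 to compound 4 (0.90 log units; beyond the scatter) shows a modest step from the carboxylic acid to the butyl ester. No available evidence gives a reason for the size of the fluoro step.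

From the compounds shown here alone, only the butyl ester has a direct fluoro-for-hydrogen comparison, so the size of this step on the methyl ester or the carboxylic acid remains open. Going by these compounds, it is also open how a methoxy group or a nitrile on the same aromatic carbon would compare with fluoro, and whether an ester chain longer than butyl would stay within the scatter of compound 2 and compound 4.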